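Swapping the chlorophenyl group for a biphenyl group

This account rests on a few compounds, and the source may have more. Where it says the series, first, only, none or still open, it means among the compounds named here.

Measured compounds:
Compound 1, `Nc1ccccc1NC(=O)/C=C/c1ccc(COCNc2nc(Nc3cccc(Cl)c3)c3ncn(C4CCCC4)c3n2)cc1`: 46.1%
Compound 2, `Nc1ccccc1NC(=O)c1ccc(COCNc2nc(Nc3ccccc3)c3ncn(C4CCCC4)c3n2)cc1`: 56.1%
Compound 3, `Nc1ccccc1NC(=O)c1ccc(COCNc2nc(Nc3cccc(Cl)c3)c3ncn(C4CCCC4)c3n2)cc1`: 49.2%

In a functional assay on NCI-H460 cells (Homo sapiens) for antiproliferative activity, read by CCK-8 assay, with a stated time of 72 h, tested at 8 uM (on this read-out higher numbers stand for a stronger effect at the one concentration tested and lower numbers for a weaker effect), compound 3 stands second highest of the three numbers. Its nearest neighbour is compound 1, with a number 3.1 percentage points higher from compound 1 to compound 3 (within the scatter), and its furthest is compound 2, with a number 6.9 percentage points lower from compound 2 to compound 3 (within the scatter); both of these steps lie within the scatter, so the three values cannot be ordered.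

Compound 4, `Nc1ccccc1NC(=O)c1ccc(COCNc2nc(Nc3ccc(-c4ccccc4)cc3)c3ncn(C4CCCC4)c3n2)cc1`, differs from compound 3 in one place: 4-phenylphenyl in place of 3-chlorophenyl on a nitrogen on an aromatic ring. For the measured compounds named here, of the two measured steps, only the one from compound 2 to compound 3 touches the same ring on that nitrogen, and it was small; the step from compound 1 to compound 3 sits elsewhere and does not bear on this change. Going by the values given here, no measured pair covers a 4-phenylphenyl group, so the data give no direction for the step. The expected step in this assay is therefore a number 1.2 percentage points lower from compound 3 to compound 4 (within the scatter), none beyond the scatter. The estimate for compound 4 is 48%, with a range from 30% to 65%.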

Compound 4, a percentage reported as inhibition, at one concentration (the size of the read-out at that concentration, not a potency): 41.6%
The estimate for compound 4 lay 6.4 percentage points above the measured number, and the stated range covers the measured number.
By their numbers in this assay, from the lowest: compounds 4, 1, 3 and 2 (each within the scatter of the next, the first and the last beyond it).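

In this assay, for the compounds shown here, the ring on this nitrogen gives a step beyond the scatter for the first time, though a modest one: a number 14.5 percentage points lower from compound 2 to compound 4 (beyond the scatter), where compound 4 carries an added phenyl ring. Against the 3-chlorophenyl group the 4-phenylphenyl group gives no readable change, a number 7.6 percentage points lower from compound 3 to compound 4 (within the scatter), so the larger group, with 12 heavy atoms against 7, is separated only from the unsubstituted phenyl of compound 2. Nothing available explains why the added phenyl ring lowers the number from that of compound 2.

The compounds shown leave open whether this step belongs to a second aromatic ring as such or would also appear with a methoxy group, an amine or a carboxylic acid on that ring. They also leave open whether a single concentration reflects the difference that a full concentration series would show.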